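Moving the chlorine on the benzyl arm of compound 3

The compounds below may be only part of what the source reports. "The series", "measured", "known", "first", "only" and "open" are said of these compounds alone.

Of the compounds shown here, three that share one core have been tested in a functional assay on the whole organism (artery, strain albino) with Rattus norvegicus as the target, with a stated time of 360 min, at a dose of 10 mg/kg by the oral route; a lower number here means less inhibition, a higher number more inhibition at the dose given (going by the name of the read-out). Compound 1 `CC1=C(C(=O)Nc2ccc([N+](=O)[O-])cc2)C(c2ccc(Br)cc2)N=C(SCc2cccc(Cl)c2)N1` gives 7.2%. Compound 2 `CC1=C(C(=O)Nc2ccc([N+](=O)[O-])cc2)C(c2cccc([N+](=O)[O-])c2)N=C(SCc2ccccc2)N1` gives 32.5%, and compound 3 `CC1=C(C(=O)Nc2ccc([N+](=O)[O-])cc2)C(c2cccc([N+](=O)[O-])c2)N=C(SCc2ccccc2Cl)N1` gives 17.5%. Compound 3 thus stands second highest of the three, separated from both other compounds by more than the scatter. Among the measured compounds shown here, the only single-point step among the measured compounds is a number 15 percentage points lower from compound 2 to compound 3 (beyond the scatter), a modest fall. Compound 4 `CC1=C(C(=O)Nc2ccc([N+](=O)[O-])cc2)C(c2cccc([N+](=O)[O-])c2)N=C(SCc2cccc(Cl)c2)N1` differs from compound 3 by 3-chlorophenyl in place of 2-chlorophenyl on a saturated chain carbon bound to a sulfur.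

For the measured compounds named here, no measured step covers exactly this change. Going by the values given here, compound 1 also carries a 3-chlorobenzyl group, but it differs from compound 3 in a second place as well, so its value shows only that a compound bearing that group sits lowest of the three. The step from compound 2 to compound 3 shows that inhibition fell when chlorine was added to this ring; with the chlorine shifted to its new position, that loss is expected to remain and possibly deepen a little. Compound 4 is therefore expected to give 13%, within a range from 3% to 27%. The expected step is a number 4.5 percentage points lower from compound 3 to compound 4 (within the scatter), at or near the edge of the scatter.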

Compound 4, a percentage reported as inhibition, in the whole organism at one dose (the size of the read-out at that dose, not a potency): 21.6%
Compound 4: middle estimate off by 8.6 percentage points, on the low side; low and high end bracket the measured number.
By their numbers in this assay, from the lowest: compound 1; then compounds 3 and 4 (each within the scatter of the next); then compound 2.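

In this assay, moving the chlorine gives a number 4.1 percentage points higher from compound 3 to compound 4 (within the scatter), so the 2-chlorobenzyl and 3-chlorobenzyl groups cannot be told apart at this position. Adding the chlorine in its new position to the unsubstituted benzyl group gives a number 10.9 percentage points lower from compound 2 to compound 4 (beyond the scatter), and read beside a number 15 percentage points lower from compound 2 to compound 3 (beyond the scatter), this shows that both chlorinated compounds fall below compound 2, not just the one with the 2-chlorobenzyl group. Among the compounds shown here, with the 3-chlorobenzyl arm now held constant, the other ring can also be read on its own for the first time: 3-nitrophenyl in place of 4-bromophenyl on a saturated ring carbon gives a number 14.4 percentage points higher from compound 1 to compound 4 (beyond the scatter). Nothing available here explains any of these differences.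

On these data alone, it remains open whether a methoxy group, an amine or a carboxylic acid in place of the chlorine would lift inhibition back towards that of compound 2, or whether a longer chain in place of the benzyl arm would change the picture. As far as these compounds go, it is also open whether the gain from the 3-nitrophenyl group would hold with an unsubstituted benzyl arm or a 2-chlorobenzyl arm.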